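The compounds below may be only part of what the source reports. "The series", "measured", "known", "first", "only" and "open" are said of these compounds alone.

Of the compounds shown here, three built on one shared core have been measured in a functional assay for agonist activity at G protein-coupled receptor 88 (Homo sapiens), read by HTRF and cAMP accumulation; a higher number here means that more compound is needed for the effect, a lower number that less compound is needed. Compound 1 `CC[C@H](C)[C@@H](CN(C(=O)[C@@H]1C[C@H]1c1ccccc1)c1ccc(-c2ccccc2)cc1)NC(C)=O` gives 5.8 nM. Compound 2 `CC(C)C[C@H](N)CN(C(=O)[C@@H]1C[C@H]1c1ccccc1)c1ccc(-c2ccc(F)cc2)cc1` gives 900 nM, and compound 3 `CC[C@H](C)[C@H](N)CN(C(=O)[C@@H]1C[C@H]1c1ccccc1)c1ccc(-c2ccc(C(C)(C)C)cc2)cc1` gives 750 nM. Among these three numbers compound 3 stands second highest; its value and that of compound 2 lie within the scatter of each other, so no order can be drawn between the two, whereas compound 1 sits far lower, well beyond the scatter.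

The piece now follows the step from compound 3 to compound 4 `CC[C@H](C)[C@H](N)CN(C(=O)[C@@H]1C[C@H]1c1ccccc1)c1ccc(-c2ccc(C(=O)N(C)C)cc2)cc1`, which has not yet been measured. The change is dimethylcarbamoyl in place of tert-butyl on an aromatic carbon. Among the compounds with values here, no pair among the measured compounds shows this difference on its own, so there is no measured step to lean on; compounds 2 and 3 differ both in the side chain and in the group on the outer ring, and their values show only that those two changes together leave the number within the scatter.

The step expected here is a 1.9-fold lower number from compound 3 to compound 4 (0.27 log units; within the scatter), modest and, if anything, toward a lower number. Compound 4 is estimated at 400 nM, with a range from 80 nM to 2000 nM.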

Compound 4, half-maximal effective concentration: 980 nM
The estimate for compound 4 lay 2.5-fold (0.39 log units) below the measured number; low and high end bracket the measured number.
By their numbers in this assay, from the lowest: compound 1; then compounds 3, 2 and 4 (each within the scatter of the next).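

Within the data shown here, the swap of tert-butyl for dimethylcarbamoyl, on an aromatic carbon para to a large group, is the first change at this place that can be read on its own: in this assay it gives a 1.3-fold higher number from compound 3 to compound 4 (0.12 log units; within the scatter). The two groups are not alike in their atoms, since tert-butyl is all carbon with no hydrogen-bond acceptor, while dimethylcarbamoyl brings a nitrogen, an oxygen, a double bond and one hydrogen-bond acceptor, yet the values of compound 3 and compound 4 cannot be told apart, so on this side chain the place tolerates both groups without a measurable difference. Nothing measured here explains this result.

Going by these compounds, only these two groups have been compared directly at this place on this side chain, so it remains open whether a carboxylic acid, a primary amide or a small group such as methoxy would also leave the number unchanged. On these data alone, it is also open whether dimethylcarbamoyl would be tolerated equally on the core of compound 1, which carries an acetylated nitrogen and has no group on its outer ring.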